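Aryl amine variation on the quinone sulfonylamidine series

A few compounds are considered here, and "the series" means these few. Any claim that something is new, unique, unknown or untested is made for them only; others in the source may bear on it.

Three compounds share one core and differ only in the aryl group on the amine nitrogen. Compound 1 `Cc1ccc(S(=O)(=O)/N=C(/CCNC2=CC(=O)c3ccccc3C2=O)Nc2ccc(Cl)cc2)cc1` carries a 4-chlorophenyl and gives in an ADME assay on HEK293 cells (Homo sapiens) for cytotoxicity, read by MTT assay, with a stated time of 48 h (on this read-out lower numbers stand for stronger inhibition and higher numbers for weaker inhibition), a value of 65400 nM. Compound 2 `Cc1ccc(S(=O)(=O)/N=C(/CCNC2=CC(=O)c3ccccc3C2=O)Nc2ccccc2[N+](=O)[O-])cc1` carries a 2-nitrophenyl and gives in this assay 69600 nM. Compound 3 `Cc1ccc(S(=O)(=O)/N=C(/CCNC2=CC(=O)c3ccccc3C2=O)Nc2cccc(C(F)(F)F)c2)cc1` carries a 3-(trifluoromethyl)phenyl and gives in this assay 91500 nM. Compound 3 is not separated from either of the others beyond the scatter: the steps are a 1.4-fold higher number from compound 1 to compound 3 (0.15 log units; within the scatter) and a 1.3-fold higher number from compound 2 to compound 3 (0.12 log units; within the scatter), and the third pair shows a 1.1-fold higher number from compound 1 to compound 2 (0.03 log units; within the scatter).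

Compound 4 `Cc1ccc(S(=O)(=O)/N=C(/CCNC2=CC(=O)c3ccccc3C2=O)Nc2ccc(F)c(F)c2)cc1` is not yet measured. The change from compound 3 is 3,4-difluorophenyl in place of 3-(trifluoromethyl)phenyl on an amine nitrogen. All three measured steps bear on it, since each also exchanges the aryl group on that amine nitrogen, and none of them left the scatter. The expected step in this assay is therefore none beyond the scatter, a 1.2-fold lower number from compound 3 to compound 4 (0.09 log units; within the scatter). Compound 4 is estimated at 75000 nM, with a range from 40000 nM to 140000 nM.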

Compound 4, half-maximal inhibitory concentration: 55200 nM
Estimate against measurement, compound 4: 1.4-fold (0.13 log units) above; the measured number falls inside the stated range.
By their numbers in this assay, from the lowest: compounds 4, 1, 2 and 3 (each within the scatter of the next).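

In this assay the amine nitrogen now carries a fourth aryl group, and the step to 3,4-difluorophenyl in place of 3-(trifluoromethyl)phenyl stays within the scatter: the steps are a 1.7-fold lower number from compound 3 to compound 4 (0.22 log units; within the scatter) and a 1.3-fold lower number from compound 2 to compound 4 (0.10 log units; within the scatter) and a 1.2-fold lower number from compound 1 to compound 4 (0.07 log units; within the scatter) and none of them leaves it. Even the pair furthest apart of the four compounds, compound 3 and compound 4, is not separated, so the aryl groups shown set no order at this position. No measurement at hand offers an explanation for this flat result.

Every aryl group shown is a substituted phenyl, so an unsubstituted phenyl, a pyridine ring or a cyclohexyl group on this nitrogen remains open. Also open, on these data alone, is whether a carboxylic acid on the aryl ring or a longer chain on the shared core would move the number beyond the scatter.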